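Removing one carboxymethyl from compound 2

The source may hold more compounds than are shown below. What is called first, only, known or untested is meant among the compounds shown, and "the series" means these compounds.

Compound 2 `COc1ccc(-c2oc3c(CC=C(C)C)c(OCC(=O)O)cc(O)c3c(=O)c2OCC(=O)O)cc1` gives > 100000 nM in a functional assay on A549 cells (Homo sapiens) for cytotoxicity, read by MTT assay (on this read-out higher numbers stand for weaker inhibition and lower numbers for stronger inhibition), which is a limit of the assay and not a number. It therefore has no measured position in the series. Compound 1 `COc1ccc(-c2oc3c(CC=C(C)C)c(OC(C)C(=O)O)cc(O)c3c(=O)c2O)cc1` gives a true number in this assay, 15300 nM. Among the compounds with values here, no measured step connects these two compounds.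

Compound 3 `COc1ccc(-c2oc3c(CC=C(C)C)c(OCC(=O)O)cc(O)c3c(=O)c2O)cc1` differs from compound 2 at one place: hydrogen in place of carboxymethyl on an oxygen on an aromatic ring. This is hydrogen in place of carboxymethyl on an oxygen on an aromatic ring, or carboxymethoxy to hydroxy.

The expectation rests on compound 1 at 15300 nM, which also carries hydrogen on that oxygen. A change towards stronger inhibition in this assay, beyond the scatter, is therefore expected, with an estimated at least 4.5-fold lower number from compound 2 to compound 3 (0.65 log units; beyond the scatter). A reading at the limit remains possible. For compound 3 the estimated value is 22000 nM, with an expected range of 8000 nM to 60000 nM.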

Compound 3, half-maximal inhibitory concentration: 16700 nM
For compound 3 the middle estimate is 1.3-fold (0.12 log units) above the measured one, and the stated range covers the measured number.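

In this assay, hydrogen in place of carboxymethyl on this oxygen gives an at least 5.9-fold lower number from compound 2 to compound 3 (0.77 log units; beyond the scatter), so the change turns a reading at the limit into a true number. The size of this step has only a lower bound because compound 2 stands at a limit of the assay and not at a number: the limit of > 100000 nM in this assay, at which 1 of the 3 values shown sits.

The second step, a 1.1-fold higher number from compound 1 to compound 3 (0.04 log units; within the scatter), shows that methyl on the saturated chain carbon of the remaining carboxymethyl makes no difference beyond the scatter in this pair.

The compounds shown leave open whether a small group such as methyl on this oxygen would also give a true number, or whether hydrogen is required. They also leave open how a longer chain or an amine in place of the remaining carboxylic acid would read.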